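The source may report more compounds than this note shows. Statements on the series, on what has been measured and on what is new or still open speak of the compounds shown alone.

Compound 2 `CNC(=O)c1cc(Oc2ccc3nc(Nc4ccc(F)cc4)ncc3c2)ccn1` carries a 4-fluorophenyl group on the shared core. In a physicochemical assay for solubility, at pH 7 (on this read-out lower numbers stand for lower solubility and higher numbers for higher solubility), compound 2 gives < 1000 nM, which is a limit of the measurement and not a number. Compound 1 `CNC(=O)c1cc(Oc2ccc3nc(Nc4cccc(Cl)c4)ncc3c2)ccn1` gives < 1000 nM in this assay, again a limit. The step that the two limits leave unreadable from compound 1 to compound 2 is therefore of unreadable size, both values sitting at the limit of < 1000 nM in this assay, at which 2 of the 2 values shown sit. Compound 3 `CNC(=O)c1cc(Oc2ccc3nc(Nc4ccc(OC(F)(F)F)cc4)ncc3c2)ccn1` differs from compound 2 by trifluoromethoxy in place of fluoro on an aromatic carbon. No measured step sizes this change, so compound 3 is expected to give 400 nM in this assay, within 80 nM to 1500 nM, an estimated step that the limit leaves unreadable from compound 2 to compound 3.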

Compound 3, solubility: < 1000 nM
Compound 3: only a limit was reported; the forecaster's own chance of this, stated with the estimate: 85%; the middle value lies beyond the limit too.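

No step can be read between compound 1, compound 2 and compound 3, as all three sit at one limit: the limit of < 1000 nM in this assay, at which 3 of the 3 values shown sit. Still open, from the compounds shown here alone, is how these three compare in this assay and whether any change to the shared core gives a value clear of that limit.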